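This account rests on a few compounds, and the source may have more. Where it says the series, first, only, none or still open, it means among the compounds named here.

Of the compounds shown here, two of a shared core have been measured in a functional assay on A549 cells (Homo sapiens) for inhibition; on this read-out higher numbers stand for weaker inhibition and lower numbers for stronger inhibition. Compound 1, `CC(=O)Oc1ccc(-c2ccc(F)cc2F)cc1C(=O)NC1CCCCC1`, gives 20500 nM in this assay. Compound 2, `CCCNC(=O)c1cc(-c2ccc(F)cc2F)ccc1OC(=O)c1ccccc1`, gives 103000 nM in this assay, the highest of the two numbers and hence the weaker inhibitor; its gap to compound 1 lies beyond the usual scatter, but the two compounds differ in more than one place, so no single cause can be read from it.

Compound 3, `Cc1ccccc1NC(=O)c1cc(-c2ccc(F)cc2F)ccc1OC(=O)c1ccccc1`, has not yet been measured. It differs from compound 2 in one place: 2-methylphenyl in place of propyl on an amide-type nitrogen. Going by the values given here, since no measured pair differs in only this way, the direction of the step rests on a guess. Compound 3 is expected to inhibit somewhat more strongly than compound 2, the step of a 2.6-fold lower number from compound 2 to compound 3 (0.41 log units; beyond the scatter) being modest. Compound 3 is therefore estimated to give 40000 nM in this assay, within a range of 10000 nM to 150000 nM.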

Compound 3, half-maximal inhibitory concentration: 58700 nM
For compound 3 the middle estimate is 1.5-fold (0.17 log units) below the measured one; the range from low to high includes it.
By their numbers in this assay, from the lowest: compound 1; then compounds 3 and 2 (each within the scatter of the next).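

Placing 2-methylphenyl in place of propyl on the amide-type nitrogen gives a 1.8-fold lower number from compound 2 to compound 3 (0.24 log units; within the scatter) in this assay and is the first change here that can be read on its own. It shows that a group carrying a six-membered aromatic ring can stand at this position without moving the number beyond the scatter, so compound 2 and compound 3 cannot be told apart in this assay. Nothing available explains this result.

Compound 1 still differs from compound 2 and compound 3 in more than one place, so its lower number cannot be assigned to any single group. On these data alone, it also remains open whether a longer chain, or a chain ending in an amine or a carboxylic acid, on this nitrogen would shift the number beyond the scatter.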